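The source may hold more compounds than are shown below. What is called first, only, known or untested is meant among the compounds shown, and "the series" means these compounds.

Measured compounds:
Compound 1 `O=S(=O)(Nc1ccc2oc(-c3ccccc3)nc2c1)c1ccccc1O`: in an ADME assay on HEK293 cells (Homo sapiens) for cytotoxicity, read by resazurin assay, with a stated time of 48 h (on this read-out lower numbers stand for higher toxicity in this test and higher numbers for lower toxicity in this test), compound 1 gives 33000 nM.
Compound 2 `COc1ccc(S(=O)(=O)Nc2ccc(-c3nc4ccccc4o3)cc2)cc1`: in this assay compound 2 reaches only the limit > 100000 nM.

For the measured compounds named here, compound 2 therefore stands not at a number but at the limit of > 100000 nM in this assay, at which 1 of the 2 values shown sits, so where it lies within the low-toxicity region is not known from these two results; compound 1 is the only one of the pair that returns a number. Compound 3 `CCc1ccc(S(=O)(=O)Nc2ccc(-c3nc4ccccc4o3)cc2)cc1` differs from compound 2 in a single place: ethyl in place of methoxy on an aromatic carbon. Going by the values given here, no step between measured compounds is available here to gauge what such a change does, and nothing about the change itself is known beyond what is counted. The step from compound 2 to compound 3 in this assay is therefore expected to be small, estimated as an at least 1.2-fold lower number from compound 2 to compound 3 (0.09 log units; that floor lies within the scatter), in no direction beyond the scatter, though compound 3 may return a number rather than a limit. The estimate for compound 3 in this assay is 80000 nM, expected to fall between 30000 nM and 200000 nM.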

Compound 3, half-maximal cytotoxic concentration: 82000 nM
For compound 3 the middle estimate is 1.0-fold (0.01 log units) below the measured one; the range from low to high includes it.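

For the compounds shown here, with ethyl in place of methoxy on an aromatic carbon, para to a large group, compound 3 gives 82000 nM in this assay and so puts the first actual number on this position of the sulfonamide series. Compound 2 stays a limit and not a number, which marks the low-toxicity end of this read-out: the limit of > 100000 nM in this assay, at which 1 of the 3 values shown sits. Read against that limit, the change from 4-methoxyphenyl to 4-ethylphenyl amounts to an at least 1.2-fold lower number from compound 2 to compound 3 (0.08 log units; that floor lies within the scatter) and is bounded on one side only, so it shows that ethyl at this place still leaves toxicity in this test low, while the full size of the step remains unknown.

The compounds shown leave open how far compound 2 lies past its limit, and therefore whether the true step from methoxy to ethyl stays within the scatter or goes beyond it. They also leave open what an amine, a carboxylic acid or a longer chain such as butyl would return at this same place in this assay and whether any such group would shift the number further than ethyl does.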